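Same atoms, joined differently: from compound 3 to compound 4

The source may hold more compounds than are shown below. What is called first, only, known or untested is meant among the compounds shown, and "the series" means these compounds.

Measured so far:
- compound 1 `CC(=O)N1CCCN(c2cccc(Nc3nccc(-c4c[nH]c5ncccc45)n3)c2)CC1` gives 20 nM
- compound 2 `CN1CCN(c2cccc(Nc3nccc(-c4cn(C)c5ncccc45)n3)c2)CC1` gives 24 nM
- compound 3 `CN1CCN(c2cccc(Nc3nccc(-c4c[nH]c5cccnc45)n3)c2)CC1` gives 405 nM

These values come from a functional assay on MV4-11 cells (Homo sapiens) for antiproliferative activity, read by resazurin assay, with a stated time of 72 h; a lower number here means a stronger inhibitor of growth, a higher number a weaker inhibitor of growth. Compound 3 has the highest number of the three, so it is the weakest growth inhibitor here.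

Compound 4 `CN1CCN(c2cccc(Nc3nccc(-c4c[nH]c5ncccc45)n3)c2)CC1` is built from the same atoms as compound 3, joined differently: a group of 9 heavy atoms (7 carbon, 2 nitrogen; one five-membered aromatic ring with 1 hetero atom, one six-membered aromatic ring with 1 hetero atom) in place of a group of 9 heavy atoms (7 carbon, 2 nitrogen; one five-membered aromatic ring with 1 hetero atom, one six-membered aromatic ring with 1 hetero atom), on an aromatic carbon. Among the compounds with values here, no measured step matches this change exactly. The closest is a 17-fold higher number from compound 2 to compound 3 (1.23 log units; beyond the scatter), a large step beyond the scatter. It touches the same place, but compound 2 also carries a methyl group there, so it is only a partial guide.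

Compound 4 has the fused group of compound 1, which gives 20 nM, and the amine end of compound 2, which gives 24 nM. Those two values lie within the scatter of each other. A large fall in the number is therefore expected, close to that step in reverse. The expected change is a 20-fold lower number from compound 3 to compound 4 (1.31 log units; beyond the scatter). Compound 4 is estimated at 20 nM, with an expected range from 7 nM to 60 nM.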

Compound 4, concentration for 50% growth inhibition: 5 nM
Compound 4: middle estimate off by 4.0-fold (0.60 log units), on the high side; measured number outside the range, below it.
By their numbers in this assay, from the lowest: compound 4; then compounds 1 and 2 (each within the scatter of the next); then compound 3.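

In this assay, the same atoms joined differently at this place give an 81-fold lower number from compound 3 to compound 4 (1.91 log units; beyond the scatter) with nothing added or removed, so the way these atoms are joined is enough on its own to produce a large change. With the better arrangement in hand, the nitrogen and the amine end also prove to matter: hydrogen in place of methyl on the aromatic nitrogen gives a 4.8-fold lower number from compound 2 to compound 4 (0.68 log units; beyond the scatter) and 4-methylpiperazin-1-yl in place of 4-acetyl-1,4-diazepan-1-yl gives a 4.0-fold lower number from compound 1 to compound 4 (0.60 log units; beyond the scatter) with both steps modest but beyond the scatter. Nothing available here gives a cause for any of these steps.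

The step from compound 1 combines two differences, the acetyl group and the ring size, and a 4-acetylpiperazin-1-yl group would be needed to separate them. As far as these compounds go, it also remains open whether an ethyl group on the aromatic nitrogen would behave like methyl.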